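Two limits in hand, a third amide to predict

The compounds below may be only part of what the source reports. "The series", "measured", "known", "first", "only" and "open" are said of these compounds alone.

Compound 1 `COc1ccc(CNC(=O)/C=C/c2coc3cc(O)ccc3c2=O)cc1` in a functional assay on L02 cells (Homo sapiens) for inhibition, read by MTT assay, with a stated time of 48 h (a lower number here means a stronger inhibitor, a higher number a weaker inhibitor), gives > 200000 nM, a limit of the assay.
Compound 2 `COc1ccc2c(=O)c(/C=C/C(=O)NCc3ccccc3F)coc2c1` in this assay gives > 200000 nM, also a limit of the assay.

Compound 2 therefore stands at the ceiling of what this assay reports rather than at a measured number. The same is true of compound 1, and this is summed up by the limit of > 200000 nM in this assay, at which 2 of the 2 values shown sit. Within the data shown here, no step between two measured compounds can be counted here, since neither compound has a number.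

Compound 3 `COc1ccc(CNC(=O)/C=C/c2coc3cc(OC)ccc3c2=O)cc1` has not yet been measured in this assay. It differs from compound 2 by 4-methoxyphenyl in place of 2-fluorophenyl on a saturated chain carbon bound to an amide-type nitrogen. Compound 3 carries, on the amide side, the same 4-methoxybenzyl that compound 1 carries, and on the core a methoxy where compound 1 carries a hydroxyl; for that pair only compound 1's limit is known.

With both measured compounds sitting at the same limit, the step that the limit leaves unreadable from compound 2 to compound 3 is expected to be none beyond the scatter, and compound 3 is expected to sit at the same limit. Compound 3 is estimated at 300000 nM, within 100000 nM to 1000000 nM.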

Compound 3, half-maximal inhibitory concentration: > 200000 nM
Compound 3: a limit, no number; the forecaster's own chance of this, stated with the estimate: 80%; the middle value lies beyond the limit too.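

In this assay compound 3 gives > 200000 nM, a limit of the assay and not a number. No step from compound 1 or compound 2 to compound 3 can be read: the limit of > 200000 nM in this assay, at which 3 of the 3 values shown sit.

The compounds shown leave open where any of the three truly lies, and so whether swapping 2-fluorobenzyl for 4-methoxybenzyl, or hydroxyl for methoxy on the core, makes any difference in this assay.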